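The compounds below may be only part of what the source reports. "The series", "measured", "known", "first", "only" and "open" are said of these compounds alone.

Three close relatives of one shared core have been tested in an assay on isolated protein for inhibition of Indoleamine 2,3-dioxygenase 1 (Homo sapiens), read by spectrophotometry, with a stated time of 1 h; on this read-out lower numbers stand for stronger inhibition and higher numbers for weaker inhibition. Compound 1 `O=[N+]([O-])c1ccc(N/C(=N\O)c2cccc(Cl)c2)c2nonc12` gives 184 nM. Compound 2 `O=[N+]([O-])c1ccc(N/C(=N\O)c2cccc(Br)c2)c2nonc12` gives 105 nM. Compound 3 `O=[N+]([O-])c1ccc(N/C(=N\O)c2ccc(F)c(Cl)c2)c2nonc12` gives 158 nM. All three numbers sit close together: a 1.8-fold lower number from compound 1 to compound 2 (0.24 log units; within the scatter), a 1.2-fold lower number from compound 1 to compound 3 (0.07 log units; within the scatter), and a 1.5-fold higher number from compound 2 to compound 3 (0.18 log units; within the scatter).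

Compound 4 `O=[N+]([O-])c1ccc(N/C(=N\O)c2ccc(F)c(Br)c2)c2nonc12` has not yet been measured. It is related to compound 3 by bromo in place of chloro on an aromatic carbon. The same kind of change has already been made once, from compound 1 to compound 2, where it reads (bromo in place of chloro on an aromatic carbon). The two cores on which the change is made differ in turn by fluoro in place of hydrogen on an aromatic carbon. The surroundings of the change are not identical: in the pair from compound 3 to compound 4 the aromatic carbon carrying the halogen is ortho to a fluoro group and meta to a large group, whereas in the pair from compound 1 to compound 2 it is only meta to a large group, so this is the same kind of change rather than the same change.

The earlier step, a 1.8-fold lower number from compound 1 to compound 2 (0.24 log units; within the scatter), stayed within the usual scatter, so it gives only a gentle hint of direction. From compound 3 to compound 4 an estimated 1.7-fold lower number from compound 3 to compound 4 (0.22 log units; within the scatter) is expected in this assay, resting on compound 1 and compound 2 with their a 1.8-fold lower number from compound 1 to compound 2 (0.24 log units; within the scatter). Compound 4 is therefore estimated at 95 nM in this assay, most likely between 50 nM and 180 nM.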

Compound 4, half-maximal inhibitory concentration: 92 nM
For compound 4 the middle estimate is 1.0-fold (0.01 log units) above the measured one; measured number inside the range.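

In this assay, putting bromo in place of chloro gives a 1.7-fold lower number from compound 3 to compound 4 (0.23 log units; within the scatter), and this step matches the same change made on the core without the fluoro group: the same change on two cores in this assay, a 1.8-fold lower number (0.24 log units; within the scatter) from compound 1 to compound 2 and a 1.7-fold lower number (0.23 log units; within the scatter) from compound 3 to compound 4, 1.0-fold (0.01 log units) apart, within the scatter of two such steps Adding the fluoro group also reads the same on both cores, with a 1.1-fold lower number from compound 2 to compound 4 (0.06 log units; within the scatter) matching the earlier step: the same change on two cores in this assay, a 1.2-fold lower number (0.07 log units; within the scatter) from compound 1 to compound 3 and a 1.1-fold lower number (0.06 log units; within the scatter) from compound 2 to compound 4, 1.0-fold (0.01 log units) apart, within the scatter of two such steps Taken together, these matches show that on these four compounds each change carries from one core to the other with no visible shift in its step, but every step here, including the double change with a 2.0-fold lower number from compound 1 to compound 4 (0.30 log units; within the scatter), lies within the usual scatter, so the data establish neither a real gain from bromo or fluoro nor that the match would hold on a different core.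

All four compounds carry only chloro, bromo or fluoro on the phenyl ring, which leaves the series tested on a narrow range of closely similar groups. From the compounds shown here alone, what an iodo, methyl or methoxy group would do in place of the halogen in this assay, and whether such a change would carry between cores as these two do, remains open.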